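The compounds below may be only part of what the source reports. "The series", "measured", "known", "first", "only" and "open" are said of these compounds alone.

Compound 1 `Cc1ccc2c(c1)[n+]([O-])c(C(=O)NCc1ccccc1)c(C)[n+]2[O-]`: in an ADME assay on Vero cells (Chlorocebus sabaeus) for cytotoxicity, read by MTT assay, with a stated time of 72 h (a higher number here means a weaker inhibitor, a lower number a stronger inhibitor), compound 1 gives only a limit, > 100 ug/mL.
Compound 2 `COc1ccc(CNC(=O)c2c(C)[n+]([O-])c3ccc(C)cc3[n+]2[O-])cc1`: in this assay compound 2 likewise gives only a limit, > 30 ug/mL.
Compound 3 `COc1ccc(CNC(=O)c2c(C)[n+]([O-])c3cc(C)c(C)cc3[n+]2[O-])cc1`: in this assay compound 3 has no single number, its entry reading "not determined" (no result reported).

Going by the values given here, compound 2 therefore stands at a limit of this assay, and it stands there alone: the only further value shown is itself a limit, and the third entry carries no number. Among the compounds with values here, the single measured step, a step that the two limits leave unreadable from compound 1 to compound 2, cannot be read in size or direction because the limit of > 100 ug/mL in this assay, at which 1 of the 3 values shown sits, and the limit of > 30 ug/mL in this assay, at which 1 of the 3 values shown sits, bound both of its ends.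

Compound 4 `COc1ccc(CNC(=O)c2c(C)[n+]([O-])c3ccc(F)cc3[n+]2[O-])cc1` differs from compound 2 by fluoro in place of methyl on an aromatic carbon. Within the data shown here, no measured step touches this exchange, so there is nothing to set the change against beyond the fact that every number reported so far is a limit. The expected step is thus a step that the limit leaves unreadable from compound 2 to compound 4, that is none beyond the scatter, with the outcome most likely again a limit rather than a number. Compound 4 is accordingly expected at 60 ug/mL, within 20 ug/mL to 150 ug/mL.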

Compound 4, half-maximal inhibitory concentration: > 30 ug/mL
Compound 4 was reported as a limit (the forecaster's own chance of this, stated with the estimate: 70%); the middle value does not contradict the limit.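

Compound 2 and compound 4 both give only limits in this assay, and the step between them, fluoro in place of methyl, cannot be read in size or direction. The compounds shown leave open whether this exchange changes the result in this assay at all.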